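The source may hold more compounds than are shown below. What is called first, only, known or untested is meant among the compounds shown, and "the series" means these compounds.

Compound 1 `CNC(=O)c1ccc(Oc2cccc(NC(=S)Nc3ccc(C)cc3)c2)nc1` gives > 100000 nM, which is a limit of the assay rather than a number.
Compound 2 `CNC(=O)c1ccc(Oc2cccc(NC(=S)Nc3ccc(Cl)cc3)c2)nc1` gives 28400 nM.
Compound 3 `CNC(=O)c1ccc(Oc2cccc(NC(=S)Nc3ccc(F)cc3)c2)nc1` gives 32700 nM.

All three were tested in a functional assay on PC-3 cells (Homo sapiens) for antiproliferative activity, read by MTT assay; on this read-out lower numbers stand for stronger inhibition and higher numbers for weaker inhibition. Compound 3 and compound 2 sit close together, as the step of a 1.2-fold higher number from compound 2 to compound 3 (0.06 log units; within the scatter) shows; compound 1 stands apart only as a limit (the limit of > 100000 nM in this assay, at which 1 of the 3 values shown sits). Compound 4 `CNC(=O)c1ccc(Oc2cccc(NC(=S)Nc3ccc(OC(F)(F)F)cc3)c2)nc1` differs from compound 3 in one place: trifluoromethoxy in place of fluoro on an aromatic carbon. Going by the values given here, the steps that bear on this change are an at least 3.5-fold lower number from compound 1 to compound 2 (0.54 log units; beyond the scatter) and an at least 3.0-fold lower number from compound 1 to compound 3 (0.48 log units; beyond the scatter), both beyond the scatter, and a 1.2-fold higher number from compound 2 to compound 3 (0.06 log units; within the scatter), which lies within it. Replacing one halogen by another at this position therefore moved the number little, while replacing methyl moved it more. Trifluoromethoxy has not been tested here, so the expectation for compound 4 rests on the spread seen among compound 2 and compound 3, and a change within the scatter is expected in this assay, expressed as a 1.1-fold lower number from compound 3 to compound 4 (0.04 log units; within the scatter). The value for compound 4 is estimated at 30000 nM, with a range from 10000 nM to 100000 nM.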

Compound 4, half-maximal inhibitory concentration: > 100000 nM
Compound 4 was reported as a limit; the forecaster's own chance of this, stated with the estimate: 20%; middle value at least 3.3-fold (0.52 log units) from the limit.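

In this assay compound 4 is reported only as a limit of the assay, not as a number: the limit of > 100000 nM in this assay, at which 2 of the 4 values shown sit.

Even so, the limit is enough to show a loss of activity against both halogen compounds, with an at least 3.0-fold higher number from compound 3 to compound 4 (0.48 log units; beyond the scatter) and an at least 3.5-fold higher number from compound 2 to compound 4 (0.54 log units; beyond the scatter), both beyond the scatter, so the earlier near-equality of chloro and fluoro does not extend to trifluoromethoxy at this aromatic carbon. Compound 1 also gives a limit, so the step from compound 1 to compound 4 cannot be read, and methyl and trifluoromethoxy cannot be ranked against each other.

Going by these compounds, whether an amine, a hydroxyl or a carboxylic acid at this position would give a readable number stays open. Also open is what separates chloro and fluoro from methyl and trifluoromethoxy, since these compounds show the difference but give no cause for it.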